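This account rests on a few compounds, and the source may have more. Where it says the series, first, only, none or still open, it means among the compounds named here.

Compound 1 `CCOc1ccc(COc2c(OC)cc(/C=C/C(=O)OCC(=O)Nc3ccc(Cl)cc3)cc2OC)cc1` and compound 2 `COCOc1cc(/C=C/C(=O)OCC(=O)Nc2ccc(Cl)cc2)ccc1OCc1ccccc1` share a common core and an ester linked to an amide. In a functional assay on ECa-109 cells (Homo sapiens) for cytotoxicity, read by MTT assay, with a stated time of 72 h (a higher number here means a weaker inhibitor, a lower number a stronger inhibitor), compound 1 gives only a limit, > 200000 nM. In this assay compound 2 also gives only a limit, > 200000 nM. Compound 2 therefore stands at the limit of > 200000 nM in this assay, at which 2 of the 2 values shown sit. Compound 3 `COCOc1cc(/C=C/C(=O)OCC(=O)NN2CCOCC2)ccc1OCc1ccccc1` differs from compound 2 by morpholin-4-yl in place of 4-chlorophenyl on an amide-type nitrogen. Within the data shown here, no measured step between compounds is available here. The change is expected to bring no movement beyond the scatter, a step that the limit leaves unreadable from compound 2 to compound 3. Compound 3 is estimated at 300000 nM, within a range from 100000 nM to 1000000 nM.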

Compound 3, half-maximal inhibitory concentration: 143000 nM
Estimate against measurement, compound 3: 2.1-fold (0.32 log units) above; low and high end bracket the measured number.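

In this assay compound 3 alone among the compounds shown gives a number rather than a limit, so morpholin-4-yl in place of 4-chlorophenyl on an amide-type nitrogen brings the read-out into measurable range. Going by these compounds, the change reads as an at least 1.3-fold lower number from compound 2 to compound 3 (0.14 log units; that floor lies within the scatter), and its true size stays open on one side. The other two values are limits: the limit of > 200000 nM in this assay, at which 2 of the 3 values shown sit.

The compounds shown leave open whether morpholin-4-yl has the same effect on the core of compound 1. They also leave open how a piperidin-1-yl group or a simple amine would read on this nitrogen.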